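A few compounds are considered here, and "the series" means these few. Any claim that something is new, unique, unknown or untested is made for them only; others in the source may bear on it.

Working notes on the series. Among the measured compounds shown here, compound 1 `COC(=O)c1ccc(N2CCC(O)(Cn3cnc4c(Br)n(C)nc4c3=O)CC2)c(Cl)c1` is so far the only member with a number: in an assay on Sf21 cells for inhibition of ubiquitin carboxyl-terminal hydrolase 7 (Homo sapiens), read by spectrophotometry, with stated times of 30 min and 2 h (on this read-out higher numbers stand for weaker inhibition and lower numbers for stronger inhibition), compound 1 gives 157 nM. Compound 2 `O=c1c2cnn(-c3ccc(F)cc3)c2ncn1CC1(O)CCN(Cc2ccccc2)CC1` carries a benzyl group on the ring amine nitrogen and a fluorophenyl on the shared core; in this assay compound 2 gives "not determined" (no result reported), no result being reported. Compound 3 `Cc1ccccc1CN1CCC(O)(Cn2cnc3c(cnn3-c3ccc(F)cc3)c2=O)CC1` is the 2-methylbenzyl analogue of compound 2; in this assay compound 3 gives "not determined" (no result reported), no result being reported either, so compound 3 stands without a number, as does compound 2. Compound 4 `COC(=O)c1ccc(CN2CCC(O)(Cn3cnc4c(cnn4-c4ccc(F)cc4)c3=O)CC2)c(Br)c1` is not yet measured. It differs from compound 3 by 2-bromo-4-(methoxycarbonyl)phenyl in place of 2-methylphenyl on a saturated chain carbon bound to an amine nitrogen in a ring. The entering group resembles the aryl group of compound 1, but compound 1 carries its aryl directly on the ring amine nitrogen and on a different core, so the two are not directly comparable. For the measured compounds named here, no step between measured compounds exists to size this change in this assay, and with compound 3 unmeasured no direction can be read; the change is taken as open in direction, of unknown size. Compound 4 is expected to fall near 200 nM in this assay, with an estimated range of 30 nM to 1500 nM, an expectation resting only on compound 1 giving 157 nM with a closely related group present.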

Compound 4, half-maximal inhibitory concentration: 900 nM
Compound 4: the middle estimate sits 4.5-fold (0.65 log units) below what was measured; the range from low to high includes it.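

No step can be read from compound 3 to compound 4, as compound 3 has no single number in this assay. The compounds shown leave open how 2-bromo-4-(methoxycarbonyl)benzyl compares with 2-methylbenzyl on the shared core. No supporting evidence bears on this result.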